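Swapping the aryl group on a piperazine for an amide chain

The source may report more compounds than this note shows. Statements on the series, on what has been measured and on what is new or still open speak of the compounds shown alone.

Compound 1 `O=c1nc(N2CC[C@@H](c3ccc(F)cc3)[C@H](O)C2)sc2c([N+](=O)[O-])cc(C(F)(F)F)cc12`: 68400 nM
Compound 2 `COc1cc(OC)cc(N2CCN(c3nc(=O)c4cc(C(F)(F)F)cc([N+](=O)[O-])c4s3)CC2)c1`: > 101000 nM

In a toxicity assay on HeLa cells (Homo sapiens) for cytotoxicity, read by colorimetric assay, with a stated time of 72 h (on this read-out higher numbers stand for lower toxicity in this test and lower numbers for higher toxicity in this test), compound 1 gives 68400 nM. Compound 2 stands at the limit of > 101000 nM in this assay, at which 1 of the 2 values shown sits; its result in this assay, > 101000 nM, is a limit of the assay and not a number. Compound 3 `O=C(CN1CCN(c2nc(=O)c3cc(C(F)(F)F)cc([N+](=O)[O-])c3s2)CC1)N1CCCC1` differs from compound 2 by ((pyrrolidin-1-yl)carbonyl)methyl in place of 3,5-dimethoxyphenyl on an amine nitrogen in a ring. For the measured compounds named here, no measured pair shows this change, so no shift beyond the usual scatter is expected; the step from compound 2 to compound 3 is estimated as an at least 1.0-fold lower number from compound 2 to compound 3 (0.02 log units; that floor lies within the scatter). Compound 3 is expected to give 95000 nM in this assay, most likely between 40000 nM and 150000 nM.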

Compound 3, half-maximal cytotoxic concentration: > 106000 nM
Compound 3 gave a limit, no number; the forecaster's own chance of this, stated with the estimate: 60%; middle value at least 1.1-fold (0.04 log units) from the limit.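

For the compounds shown here, compound 2 and compound 3 each gave a limit of the assay and not a number, so no step between them can be read. Which of the two is less toxic in this test stays open.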